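Swapping the Aryl Group on a Hydrazone Amide

The source may report more compounds than this note shows. Statements on the series, on what has been measured and on what is new or still open speak of the compounds shown alone.

Compound 1 `COc1cc(/C=N/NC(=O)CCN2CCN(c3ccnc4cc(Cl)ccc34)CC2)ccc1O` gives 9400 nM in an ADME assay on cells (Splenocyte, Mus musculus, strain BALB/c) for cytotoxicity, read by thymidine incorporation, with a stated time of 24 h; on this read-out higher numbers stand for weaker inhibition and lower numbers for stronger inhibition.
Compound 2 `NNC(=O)CCN1CCN(c2ccnc3cc(Cl)ccc23)CC1` shows only a limit of this assay, > 100000 nM, not a number.
Compound 3 `CC(C)Oc1ccc(/C=N/NC(=O)CCN2CCN(c3ccnc4cc(Cl)ccc34)CC2)cc1` gives 3600 nM in this assay.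

Among the two compounds with a number, compound 1 stands highest, and its nearest neighbour is compound 3, which sits a 2.6-fold lower number from compound 1 to compound 3 (0.42 log units; beyond the scatter). Compound 2, which carries a bare nitrogen instead of the whole aryl hydrazone part, sits at the limit (the limit of > 100000 nM in this assay, at which 1 of the 3 values shown sits), so the step of an at least 10-fold higher number from compound 1 to compound 2 (1.02 log units; beyond the scatter) is large.

Compound 4 `O=C(CCN1CCN(c2ccnc3cc(Cl)ccc23)CC1)N/N=C/c1ccccc1O` is not yet measured. It differs from compound 1 by 2-hydroxyphenyl in place of 4-hydroxy-3-methoxyphenyl on a carbon with a double bond to nitrogen. The aryl ring is kept, so the large loss seen in the step to compound 2 should not apply; the step to compound 3 shows that changing the groups on that ring moves the number only modestly. A step of similar, modest size in either direction is therefore expected in this assay, most likely a slight rise as a donor and an acceptor are lost.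

Compound 4 is estimated at 12000 nM, between 4000 nM and 40000 nM, meaning an expected step of a 1.3-fold higher number from compound 1 to compound 4 (0.11 log units; within the scatter).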

Compound 4, half-maximal inhibitory concentration in the Splenocyte assay: 11500 nM
The estimate for compound 4 lay 1.0-fold (0.02 log units) above the measured number; the measured number falls inside the stated range.
By their numbers in the Splenocyte assay, from the lowest: compound 3; then compounds 1 and 4 (each within the scatter of the next). At a limit, above all of these: compound 2.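

On this carbon with a double bond to nitrogen, 2-hydroxyphenyl can stand in for 4-hydroxy-3-methoxyphenyl without a clear shift in the Splenocyte assay (a 1.2-fold higher number from compound 1 to compound 4 (0.09 log units; within the scatter)), while 4-isopropoxyphenyl remains distinct from it (a 3.2-fold higher number from compound 3 to compound 4 (0.50 log units; beyond the scatter)). Compound 2 stands at a limit of that assay rather than at a number, so the step to the smaller 2-hydroxyphenyl hydrazone is only a bound (an at least 8.6-fold lower number from compound 2 to compound 4 (0.93 log units; beyond the scatter)). The same swap is not silent everywhere: in a physicochemical assay for inhibition, read by spectrophotometry, with a stated time of 24 h, tested at 2.5 mM (a lower number here means less inhibition, a higher number more inhibition at the concentration tested (going by the name of the read-out)), compound 1 gives 50.7% and compound 4 gives 83.2% (a number 32.5 percentage points higher from compound 1 to compound 4 (beyond the scatter)).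

Why one change separates the two read-outs so differently stays open. A plain phenyl or a 2-aminophenyl ring at this place would test whether the hydroxy group matters in either assay.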